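A few compounds are considered here, and "the series" means these few. Any claim that something is new, unique, unknown or untested is made for them only; others in the source may bear on it.

Compound 1 `O=c1c(/C=C/c2ccccn2)coc2ccc(Cl)cc12`: > 50000 nM
Compound 2 `O=c1c(/C=C/c2ccncc2)coc2ccccc12`: > 100000 nM

In an ADME assay on HeLa cells (Homo sapiens) for cytotoxicity, read by XTT assay, with a stated time of 3 days (on this read-out higher numbers stand for lower toxicity in this test and lower numbers for higher toxicity in this test), compound 2 gives > 100000 nM, which is a limit of the assay and not a number. Compound 1 gives > 50000 nM, which is also a limit. Among the compounds with values here, compound 2 therefore has no exact value, and no measured step between compounds is available to show how large a structural change might be.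

The next compound, compound 3 `O=c1c(/C=C/c2ccncc2)coc2ccc(Cl)cc12`, comes from compound 2 through a single change: chloro in place of hydrogen on an aromatic carbon. In this assay, little change is expected, perhaps none beyond the scatter, and any shift should be small and towards lower numbers. This expectation rests on compound 1, which gives a limit too, > 50000 nM. The estimated step is an at least 1.4-fold lower number from compound 2 to compound 3 (0.15 log units; that floor lies within the scatter). For compound 3, the estimated value is 70000 nM, with an expected range of 25000 nM to 120000 nM. The assay may well report only a limit again.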

Compound 3, half-maximal cytotoxic concentration: 150000 nM
Compound 3: the middle estimate sits 2.1-fold (0.33 log units) below what was measured; the whole stated range lies below it.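

In this assay compound 3 gives 150000 nM. Compound 1 and compound 2 each give only a limit of the assay, so neither step to compound 3 can be read. The compounds shown leave open whether chloro in place of hydrogen, or pyridin-4-yl in place of pyridin-2-yl, changes this read-out at all, and by how much.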